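The compounds below may be only part of what the source reports. "The series", "measured", "known", "first", "only" and "open" are said of these compounds alone.

Measured compounds:
Compound 1 `CCOc1ccc([C@@H]2CC(=O)c3cc(CC=C(C)C)c(OC)cc3O2)cc1`: 60%
Compound 2 `COc1ccc([C@@H]2C/C(=N/OCc3cn(-c4ccc(C(=O)c5ccccc5)cc4)nn3)c3cc(CC=C(C)C)c(OC)cc3O2)cc1`: 40%
Compound 3 `COc1ccc([C@@H]2C/C(=N/O)c3cc(CC=C(C)C)c(OC)cc3O2)cc1`: 45%

In a functional assay on PC-3 cells (Homo sapiens) for inhibition, read by sulforhodamine B assay, with a stated time of 48 h, tested at 50 uM (on this read-out lower numbers stand for less inhibition of growth and higher numbers for more inhibition of growth at the one concentration tested), compound 1 gives the highest of the three numbers. Compound 3 comes nearest, with a value lower by a margin beyond the scatter, and compound 2 lies furthest, also beyond the scatter, so compound 1 is the most active of the measured set. Compound 4 `C#CCOc1ccc([C@@H]2CC(=O)c3cc(CC=C(C)C)c(OC)cc3O2)cc1` differs from compound 1 by one change: ethynyl in place of methyl on a saturated chain carbon bound to an oxygen on an aromatic ring. For the measured compounds named here, no measured pair shows this change, so its effect in this assay is unknown. Since the rest of the core is unchanged, the estimated step of a number 2 percentage points lower from compound 1 to compound 4 (within the scatter) is expected to stay within the usual scatter. Compound 4 is therefore expected to give about 58%, within a range from 40% to 75%.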

Compound 4, percent growth inhibition at one concentration: 52%
Estimate against measurement, compound 4: 6 percentage points above, within the range that was stated.
By their numbers in this assay, from the lowest: compounds 2, 3, 4 and 1 (each within the scatter of the next, the first and the last beyond it).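

In this assay, putting ethynyl in place of methyl on a saturated chain carbon bound to an oxygen on an aromatic ring gives a number 8 percentage points lower from compound 1 to compound 4 (within the scatter) and so leaves the read-out unable to separate ethoxy from propargyloxy. For the compounds shown here, this is the first single-change comparison in the set, and it shows that this position accepts the triple bond with the shared core unchanged. As far as these compounds go, whether a longer chain, a carboxylic acid or an amine at this place would keep the activity in this assay remains open. The data offer no measured explanation for this step.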